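From pyridin-2-yl to pyridin-3-yl on a shared core

A few compounds are considered here, and "the series" means these few. Any claim that something is new, unique, unknown or untested is made for them only; others in the source may bear on it.

Of the compounds shown here, three have been measured in a functional assay (Homo sapiens) for antiproliferative activity; on this read-out lower numbers stand for stronger inhibition of growth and higher numbers for weaker inhibition of growth. Compound 1 (`Cc1cn2c(/C=N/NC(=N)N)c(-c3cccnc3)nc2s1`) gives 51300 nM, and compound 2 (`N=C(N)N/N=C/c1c(-c2cc([N+](=O)[O-])c(Cl)cc2Cl)nc2sc(Cl)cn12`) gives 44700 nM. Compound 3 (`N=C(N)N/N=C/c1c(-c2ccccn2)nc2sc(Cl)cn12`) gives 13200 nM, the lowest of the three numbers, and its distance from each of the other two lies beyond the usual scatter.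

Compound 4 (`N=C(N)N/N=C/c1c(-c2cccnc2)nc2sc(Cl)cn12`) has not yet been measured. It carries pyridin-3-yl in place of pyridin-2-yl on an aromatic carbon. Among the measured compounds shown here, no measured pair of compounds shows this change alone. Compound 1 also carries pyridin-3-yl and gives 51300 nM, but it differs from compound 4 elsewhere on the core and is only a loose guide. In this assay, a small rise toward weaker inhibition of growth is expected, not clearly beyond the scatter. The expected change is a 1.7-fold higher number from compound 3 to compound 4 (0.22 log units; within the scatter). For compound 4 the estimated value is 22000 nM, with an expected range from 9000 nM to 50000 nM.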

Compound 4, concentration for total growth inhibition: 42700 nM
Estimate against measurement, compound 4: 1.9-fold (0.29 log units) below, within the range that was stated.
By their numbers in this assay, from the lowest: compound 3; then compounds 4, 2 and 1 (each within the scatter of the next).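

In this assay, pyridin-3-yl in place of pyridin-2-yl on an aromatic carbon gives a 3.2-fold higher number from compound 3 to compound 4 (0.51 log units; beyond the scatter) as its result, the first measured case of this change alone, so the attachment point of the pyridine matters on this carbon even though the two groups have the same atoms. With pyridin-3-yl held in place, chloro in place of methyl gives a 1.2-fold lower number from compound 1 to compound 4 (0.08 log units; within the scatter) as its step, so this exchange on the shared core cannot be told apart from the scatter. Nothing available explains the difference between the two pyridine attachments.

The compounds shown leave open how pyridin-4-yl or an unsubstituted phenyl ring would behave on this carbon. They also leave open whether methyl in place of chloro would matter with pyridin-2-yl on the core.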